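Moving a Methoxy Group Around a Phenyl Ring

The source may hold more compounds than are shown below. What is called first, only, known or untested is meant among the compounds shown, and "the series" means these compounds.

Measured compounds:
compound 1 `COc1cccc(-c2ccc([C@H]3S[C@@H](C)C(=O)Nc4c3c(C)nn4-c3ccccc3C)cc2)c1` — 1800 nM
compound 2 `Cc1nn(-c2ccccc2Cl)c2c1C(c1ccc(Oc3ccccc3)cc1)SC(C)C(=O)N2` — 2700 nM

In an assay on isolated protein for agonist activity at Bile acid receptor (Homo sapiens), read by AlphaScreen, with a stated time of 30 min (on this read-out higher numbers stand for an effect only at larger amounts of compound and lower numbers for an effect already at smaller amounts), compound 1 gives 1800 nM. Compound 2 gives 2700 nM in this assay, and the two numbers lie within the scatter of each other, so neither can be called the more active. Compound 3 `COc1ccccc1-c1ccc([C@H]2S[C@@H](C)C(=O)Nc3c2c(C)nn3-c2ccccc2C)cc1` is not yet measured. It differs from compound 1 in one place: 2-methoxyphenyl in place of 3-methoxyphenyl on an aromatic carbon. Within the data shown here, no measured pair shows a change of this kind here, so no step beyond the scatter is expected in either direction. Compound 3 is estimated at 2200 nM, with a range of 700 nM to 7000 nM, which means an expected step of a 1.2-fold higher number from compound 1 to compound 3 (0.09 log units; within the scatter).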

Compound 3, half-maximal effective concentration: 1100 nM
The estimate for compound 3 lay 2.0-fold (0.30 log units) above the measured number, within the range that was stated.
By their numbers in this assay, from the lowest: compounds 3, 1 and 2 (each within the scatter of the next, the first and the last beyond it).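

In this assay, moving the methoxy group so that 2-methoxyphenyl replaces 3-methoxyphenyl gives a 1.6-fold lower number from compound 1 to compound 3 (0.21 log units; within the scatter), the first step measured at this place, para to a large group. So on the core of compound 1, these two arrangements of the same atoms cannot be told apart in this test. No measurement shown here offers an explanation for this result.

Still open, from the compounds shown here alone, is whether a different group at this place, such as an amine or a carboxylic acid, would produce a step beyond the scatter.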